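Replacing trifluoromethoxy with amino: what to expect

The compounds below may be only part of what the source reports. "The series", "measured", "known", "first", "only" and "open" are said of these compounds alone.

Compound 1 `COC(=O)c1ccc(NC(=O)Nc2cc(C)nc3ccccc23)cc1`: 15000 nM
Compound 2 `Cc1cc(NC(=O)Nc2ccc(C(N)=O)cc2)c2ccccc2n1`: > 25000 nM
Compound 3 `Cc1cc(NC(=O)Nc2ccc(OC(F)(F)F)cc2)c2ccccc2n1`: 14000 nM

These results come from an ADME assay on HEK293 cells (Homo sapiens) for cytotoxicity, with a stated time of 72 h; a lower number here means that less compound is needed, a higher number that more compound is needed for the effect. Compound 3 gives 14000 nM and compound 1 gives 15000 nM, so the two stand level: the step is a 1.1-fold lower number from compound 1 to compound 3 (0.03 log units; within the scatter). Compound 2 has no exact number, and its entry of > 25000 nM is a limit of the assay.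

Compound 4 `Cc1cc(NC(=O)Nc2ccc(N)cc2)c2ccccc2n1` has not yet been measured. It carries amino in place of trifluoromethoxy on an aromatic carbon, para to a large group: amino in place of trifluoromethoxy on an aromatic carbon. Amino itself has not been tested at this place, so the closest guide is what other exchanges there have done. Among the measured compounds shown here, two measured steps bear on this. One is the step already given between the level pair, and the other is an at least 1.7-fold lower number from compound 2 to compound 3 (0.25 log units; that floor lies within the scatter). Neither shows a change beyond the scatter, although the second is only a floor. On these sizes, no clear step is expected in this assay, with at most a slight drift towards a higher number: the estimated step is a 1.3-fold higher number from compound 3 to compound 4 (0.11 log units; within the scatter). The estimate for compound 4 is 18000 nM, with an expected range from 8000 nM to 40000 nM.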

Compound 4, half-maximal effective concentration: > 25000 nM
Compound 4 ended at the assay's limit; the forecaster's own chance of this, stated with the estimate: 40%; middle value at least 1.3-fold (0.14 log units) away from the limit.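

In this assay, compound 4 joins compound 2 in having a limit rather than an exact number: the limit of > 25000 nM in this assay, at which 2 of the 4 values shown sit. So amino, the smallest group shown at this place with its single heavy atom, behaves like carbamoyl in reaching that limit, whereas trifluoromethoxy and methoxycarbonyl give exact numbers. This is only a first hint, since the readable steps are floors, an at least 1.7-fold higher number from compound 3 to compound 4 (0.25 log units; that floor lies within the scatter) and an at least 1.6-fold higher number from compound 1 to compound 4 (0.22 log units; that floor lies within the scatter), and the step between compound 2 and compound 4 cannot be read, as both entries are limits.

The compounds shown leave open how far beyond the limit compound 2 and compound 4 lie, and so whether the exchange of trifluoromethoxy for amino makes a real difference in this cytotoxicity read-out or none beyond the scatter. They also leave open whether a hydroxyl group or a dimethylamino group at this place would reach the limit too, which would help to show whether the split between exact numbers and limits holds beyond these four compounds.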